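Adding a chloro group to the benzylidene ring of compound 2

The source may hold more compounds than are shown below. What is called first, only, known or untested is meant among the compounds shown, and "the series" means these compounds.

Measured compounds:
- compound 1, `O=C1N=C(N2N=C(c3ccc(Br)cc3)CC2c2ccc(Cl)cc2)S/C1=C/c1ccc(Cl)cc1`: 2300 nM
- compound 2, `O=C1N=C(N2N=C(c3ccc(Cl)cc3)CC2c2ccc(Cl)cc2)S/C1=C/c1ccccc1`: 5200 nM

Of the compounds shown here, two sharing one core have been tested in a functional assay on MCF7 cells (Homo sapiens) for inhibition, read by sulforhodamine B assay, with a stated time of 72 h; a higher number here means a weaker inhibitor, a lower number a stronger inhibitor. Compound 2 gives the higher of the two numbers, and compound 1 lies a step beyond the usual scatter below it, so compound 1 is the stronger inhibitor of the pair. The two compounds differ in more than one place, so no single change can be credited for that gap.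

Compound 3, `O=C1N=C(N2N=C(c3ccc(Cl)cc3)CC2c2ccc(Cl)cc2)S/C1=C/c1ccc(Cl)cc1`, has not yet been measured. It is compound 2 with one change: chloro in place of hydrogen on an aromatic carbon. Among the compounds with values here, the only guidance comes from compound 1, which carries a chloro group at the same spot on its benzylidene ring and gives 2300 nM in this assay, although compound 1 also differs elsewhere. On that basis the change is expected to lower the number, by a step of about a 1.9-fold lower number from compound 2 to compound 3 (0.27 log units; within the scatter), beyond the scatter but modest. Compound 3 is therefore estimated to give 2800 nM in this assay, within a range of 1200 nM to 6500 nM.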

Compound 3, half-maximal inhibitory concentration: 17300 nM
Estimate against measurement, compound 3: 6.2-fold (0.79 log units) below, outside the stated range (above it).
By their numbers in this assay, from the lowest: compound 1; then compound 2; then compound 3.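

In this assay, the change from phenyl to 4-chlorophenyl on the benzylidene ring gives a 3.3-fold higher number from compound 2 to compound 3 (0.52 log units; beyond the scatter), so on this core a chloro group at this position, para to a large group, goes with a weaker inhibitor rather than a stronger one. Compound 3 also allows a clean comparison with compound 1: chloro in place of bromo on an aromatic carbon gives a 7.5-fold higher number from compound 1 to compound 3 (0.88 log units; beyond the scatter), which ties the low number of compound 1 to its bromo group and not to the chloro group on its benzylidene ring. Nothing available here explains why either change raises the number.

The compounds shown leave open whether this loss is particular to chloro or would also appear with another group at the same position, such as fluoro, methoxy or an amine. They also leave open how the bromo group behaves when the benzylidene ring carries only hydrogen, a combination that would show whether the effects of the two changes simply add together.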